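Swapping a cyclohexyl for a hydroxypropyl chain

The compounds below may be only part of what the source reports. "The series", "measured", "known", "first", "only" and "open" are said of these compounds alone.

Measured compounds:
- compound 1, `CCCNc1nc(-c2ccccc2)nc2c1nnn2Cc1ccccc1F`, 3.2 nM
- compound 2, `Fc1ccccc1Cn1nnc2c(NC3CCCCC3)nc(-c3ccccc3)nc21`, 1.15 nM
- compound 3, `FC(F)(F)c1ccccc1Cn1nnc2c(NC3CCCCC3)nc(-c3ccccc3)nc21`, 6.8 nM

The three compounds share one core and were tested in an assay on Cerebral cortex for displacement of a labelled ligand from adenosine receptor A1 (Bos taurus); on this read-out lower numbers stand for stronger inhibition and higher numbers for weaker inhibition. Compound 2 gives the lowest number of the three; compound 1 is nearest to it, and compound 3 lies furthest away, with both differences beyond the usual scatter. The step from compound 1 to compound 2 was a 2.8-fold lower number from compound 1 to compound 2 (0.44 log units; beyond the scatter), and the step from compound 2 to compound 3 was a 5.9-fold higher number from compound 2 to compound 3 (0.77 log units; beyond the scatter).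

Compound 4, `OCCCNc1nc(-c2ccccc2)nc2c1nnn2Cc1ccccc1F`, has not yet been measured. Its change from compound 2 is 3-hydroxypropyl in place of cyclohexyl on a nitrogen on an aromatic ring. Among the compounds with values here, only one measured step touches this position: the step from compound 1 to compound 2, where a propyl chain gave way to the cyclohexyl now being removed. Replacing that cyclohexyl with a short chain again is therefore expected to move the number back toward that of compound 1, or slightly past it, since the entering group differs from propyl only by its hydroxyl. For compound 4 the expected step is a 4.3-fold higher number from compound 2 to compound 4 (0.64 log units; beyond the scatter), giving an estimate of 5 nM, within a range of 1.5 nM to 20 nM.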

Compound 4, inhibition constant: 3.7 nM
The estimate for compound 4 lay 1.4-fold (0.13 log units) above the measured number, within the range that was stated.
By their numbers in this assay, from the lowest: compound 2; then compounds 1, 4 and 3 (each within the scatter of the next, the first and the last beyond it).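

In this assay, placing a hydroxy on the propyl chain gives a 1.2-fold higher number from compound 1 to compound 4 (0.06 log units; within the scatter), so at this position the 3-hydroxypropyl chain, with its hydrogen-bond donor and acceptor, cannot be told apart from plain propyl. Replacing cyclohexyl with the hydroxylated chain gives a 3.2-fold higher number from compound 2 to compound 4 (0.51 log units; beyond the scatter), so cyclohexyl now gives the lower number against both chains tested on this nitrogen. Nothing available explains either of these results.

The compounds shown leave open whether an amine or a carboxylic acid at the end of the chain, or a longer chain carrying the hydroxy, would also leave the number unchanged. Also open, on these data alone, are a hydroxy on the cyclohexyl ring itself and the 3-hydroxypropyl chain paired with trifluoromethyl in place of fluoro.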